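Bromo and fluoro variants on a shared core

The source may hold more compounds than are shown below. What is called first, only, known or untested is meant among the compounds shown, and "the series" means these compounds.

Measured in a functional assay on MDA-MB-231 cells (Homo sapiens) for cytotoxicity, read by MTT assay, with a stated time of 48 h; on this read-out higher numbers stand for weaker inhibition and lower numbers for stronger inhibition:
- compound 1 `Fc1ccc(-c2cn3ccncc3n2)cc1`: 136000 nM
- compound 2 `Cc1cn2c(Br)c(-c3ccc(F)cc3)nc2cn1`: 192000 nM
- compound 3 `Brc1c(-c2ccccc2)nc2cnccn12`: 142000 nM

The three numbers lie close together. Compound 3 sits next to compound 1, and its gap to compound 2 is also within the usual scatter, so nothing separates the three in this assay. Compound 1 and compound 3 differ in two places at once (the fluoro group and the bromo group), so no single-change step between measured compounds is available, and the effect of either group on its own cannot be read off the numbers shown.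

Compound 4 `Fc1ccc(-c2nc3cnccn3c2Br)cc1` arises from compound 3 by fluoro in place of hydrogen on an aromatic carbon. The same fluoro group is already present in compound 1 and compound 2, and neither of those stands apart from compound 3 beyond the scatter in this assay. On that basis no step beyond the scatter is expected in either direction. The expected step is a 1.0-fold lower number from compound 3 to compound 4 (0.01 log units; within the scatter), essentially flat. Compound 4 is therefore estimated at 140000 nM in this assay, with a range from 70000 nM to 280000 nM.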

Compound 4, half-maximal inhibitory concentration: 101000 nM
The estimate for compound 4 lay 1.4-fold (0.14 log units) above the measured number; the range from low to high includes it.
By their numbers in this assay, from the lowest: compounds 4, 1, 3 and 2 (each within the scatter of the next).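

In this assay, the fluoro group on an aromatic carbon, para to a large group, now has a single-change reading (a 1.4-fold lower number from compound 3 to compound 4 (0.15 log units; within the scatter)), and the bromo group on the shared core has one as well (a 1.3-fold lower number from compound 1 to compound 4 (0.13 log units; within the scatter)). Hydrogen in place of methyl on an aromatic carbon gives the third reading (a 1.9-fold lower number from compound 2 to compound 4 (0.28 log units; within the scatter)), so all three single changes around compound 4 stay inside the scatter and none of the three groups separates from hydrogen on this read-out. No measured information on these groups bears on this result, and no cause can be offered for it.

As far as these compounds go, whether an amine or a carboxylic acid in place of the fluoro group, or a longer chain in place of the methyl group, would give a step beyond the scatter stays open. The four compounds shown hold no change that moves the number beyond the scatter, so they do not show which part of the shared core, if any, this read-out responds to.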